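Amide amine swap on two quinoline regioisomers

The source may hold more compounds than are shown below. What is called first, only, known or untested is meant among the compounds shown, and "the series" means these compounds.

Compound 1 `CCN(CC)CC(=O)Nc1ccc(Nc2nc3cc(OC)ccc3cc2-c2ccc(OC)cc2)cc1` and compound 2 `COc1ccc(-c2cc3ccc(OC)cc3nc2Nc2ccc(NC(=O)CN3CCCC3)cc2)cc1` share one core and differ only at the amide side chain. In a functional assay on HUVEC cells (Homo sapiens) for antiproliferative activity, read by MTT assay, with a stated time of 48 h (a higher number here means a weaker inhibitor, a lower number a stronger inhibitor), compound 1 gives 14000 nM and compound 2 gives 8600 nM. The change is pyrrolidin-1-yl in place of diethylamino on a saturated chain carbon bound to a carbonyl carbon and its step reads a 1.6-fold lower number from compound 1 to compound 2 (0.21 log units; within the scatter), so the two values are taken as the same.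

Compound 3 `CCN(CC)CC(=O)Nc1ccc(Nc2nc3ccc(OC)cc3cc2-c2ccc(OC)cc2)cc1` has the same atoms as compound 1 joined differently; the difference between the two cores is not broken down here. In this assay compound 3 gives 45600 nM, the highest number of the three measured, with compound 1 beyond the scatter below it and compound 2 further below.

Compound 4 `COc1ccc(-c2cc3cc(OC)ccc3nc2Nc2ccc(NC(=O)CN3CCCC3)cc2)cc1` carries the core of compound 3 with the side chain of compound 2; the change from compound 3 is pyrrolidin-1-yl in place of diethylamino on a saturated chain carbon bound to a carbonyl carbon, the same change as from compound 1 to compound 2. The step from compound 3 to compound 4 is expected to be a 1.5-fold lower number from compound 3 to compound 4 (0.18 log units; within the scatter), which rests on a 1.6-fold lower number from compound 1 to compound 2 (0.21 log units; within the scatter) and should again fall within the scatter. Compound 4 is therefore estimated at 30000 nM, with a range from 12000 nM to 75000 nM.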

Compound 4, half-maximal inhibitory concentration: 13100 nM
For compound 4 the middle estimate is 2.3-fold (0.36 log units) above the measured one, and the stated range covers the measured number.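

In this assay, pyrrolidin-1-yl in place of diethylamino on a saturated chain carbon bound to a carbonyl carbon gives a 3.5-fold lower number from compound 3 to compound 4 (0.54 log units; beyond the scatter) on the core of compound 3. Going by these compounds alone, only two pairs carry this change, and only the step on the core of compound 3 lies beyond the scatter on its own, so the data fix no reliable size for the change and do not show that it would hold on any further core. What they do show is that the step need not be treated as specific to either core, since the two steps cannot be told apart and transfer between these two cores stands as consistent:
the same change on two cores in this assay, a 1.6-fold lower number (0.21 log units; within the scatter) from compound 1 to compound 2 and a 3.5-fold lower number (0.54 log units; beyond the scatter) from compound 3 to compound 4, 2.1-fold (0.33 log units) apart, within the scatter of two such steps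

The compounds shown leave open whether other amines on the same chain carbon, such as piperidin-1-yl, morpholin-4-yl or dimethylamino, would follow the pyrrolidin-1-yl result on both cores. They also leave open whether a longer chain between the carbonyl and the amine would keep the step seen here.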